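The source may report more compounds than this note shows. Statements on the series, on what has been measured and on what is new or still open speak of the compounds shown alone.

Series notes on a small set of triazole thioethers.

In a functional assay on the whole organism (strain albino) for inhibition, with Rattus norvegicus as the target, read by paw edema, with a stated time of 2 h, at a dose of 0.28 mmol/kg by the oral route (on this read-out higher numbers stand for more inhibition at the one dose given (going by the name of the read-out) and lower numbers for less inhibition), compound 1 `CCn1c(SC/C(=N/O)c2ccccc2)nnc1-c1cc(OC)c(OC)c(OC)c1` gives 67%. Compound 3 `CCn1c(SC/C(=N/O)c2ccccc2)nnc1-c1ccc(OC)c(OC)c1` gives 67% in this assay. Compound 2 `O=C(CSc1nnc(-c2ccccc2)n1-c1ccccc1)c1ccccc1` gives 60% in this assay. Compound 4 `COc1ccc(-c2nnc(SCC(=O)c3ccccc3)n2-c2ccccc2)cc1` has not yet been measured in this assay.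

Between compound 3 and compound 1 the change is methoxy in place of hydrogen on an aromatic carbon; it gave no change at the digits printed from compound 3 to compound 1 (within the scatter). The difference between the cores of compound 2 and compound 3 is not broken down here.

Compound 4 arises from compound 2 by methoxy in place of hydrogen on an aromatic carbon. For the measured compounds named here, this is the same kind of change as the one between compound 3 and compound 1, but the place differs: in compound 1 the entering methoxy stands ortho to a methoxy group, meta to a large group and meta to a methoxy group, whereas in compound 4 it stands para to a large group.

In this assay the expected step is a number 2 percentage points higher from compound 2 to compound 4 (within the scatter), set beside the earlier no change at the digits printed from compound 3 to compound 1 (within the scatter), on the ground that this kind of change stayed within the scatter there. Compound 4 is accordingly estimated at 62% in this assay, expected to fall between 50% and 74%.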

Compound 4, a percentage reported as inhibition, in the whole organism at one dose (the size of the read-out at that dose, not a potency): 57%
Compound 4: middle estimate off by 5 percentage points, on the high side; the range from low to high includes it.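

In this assay, methoxy in place of hydrogen, para to a large group, gives a number 3 percentage points lower from compound 2 to compound 4 (within the scatter). Set beside the earlier step on the other core, this change carries from one core to the other without a difference that can be told from the scatter: the same change on two cores in this assay, no change at the digits printed (within the scatter) from compound 3 to compound 1 and a number 3 percentage points lower (within the scatter) from compound 2 to compound 4, 3 percentage points apart, within the scatter of two such steps

For the compounds shown here, this shows only that the change left the read-out within the scatter on both cores at the one dose given. It does not show that a methoxy group is without effect in general, since the entering methoxy stands at a different place in compound 1 than in compound 4, and a single dose gives no potency.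

The compounds shown leave open whether an amine or a carboxylic acid at the place taken by the methoxy in compound 4 would move the read-out beyond the scatter. Also open, on these data alone, is how the same methoxy change would read at one and the same place on both cores, and on a core with a longer chain on the sulfur.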